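A Third Substituent on the Thiocarbonyl Carbon

The compounds below may be only part of what the source reports. "The series", "measured", "known", "first", "only" and "open" are said of these compounds alone.

Of the compounds shown here, two sharing one core have been measured in a functional assay on MGC-803 cells (Homo sapiens) for antiproliferative activity, read by CCK-8 assay, with a stated time of 72 h, tested at 8 uM; on this read-out lower numbers stand for a weaker effect and higher numbers for a stronger effect at the one concentration tested. Compound 1 `CN(C(=S)SCc1ccc(C(=O)Nc2ccccc2N)cc1)c1cccnc1` gives 82.5%. Compound 2 `Nc1ccccc1NC(=O)c1ccc(CSC(=S)N2CCc3cc(Cl)ccc32)cc1` gives 82.2%. Of the two numbers, that of compound 2 is the lower, but a number 0.3 percentage points lower from compound 1 to compound 2 (within the scatter) falls within the scatter, so the two compounds cannot be told apart on this read-out.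

Compound 3 `CC1CCCCN1C(=S)SCc1ccc(C(=O)Nc2ccccc2N)cc1` has not yet been measured. It differs from compound 2 at the same place where compound 2 differs from compound 1: 2-methylpiperidin-1-yl in place of 5-chloro-2,3-dihydro-1H-indol-1-yl on a thiocarbonyl carbon. Going by the values given here, the only measured step that bears on this change, a number 0.3 percentage points lower from compound 1 to compound 2 (within the scatter), shows that exchanging the group on the thiocarbonyl carbon left the read-out unchanged within the scatter. For compound 3, therefore, no step beyond the scatter is expected in this assay, and the expected change is a number 2.2 percentage points lower from compound 2 to compound 3 (within the scatter). Compound 3 is estimated to give 80%, with a range from 66% to 90%.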

Compound 3, a percentage reported as inhibition, at one concentration (the size of the read-out at that concentration, not a potency): 86.9%
Compound 3: the middle estimate sits 6.9 percentage points below what was measured; low and high end bracket the measured number.
By their numbers in this assay, from the lowest: compounds 2, 1 and 3 (each within the scatter of the next).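

In this assay, the thiocarbonyl carbon now carries a group with no aromatic ring, and the change still cannot be separated from the scatter: the read-out gives a number 4.7 percentage points higher from compound 2 to compound 3 (within the scatter) and a number 4.4 percentage points higher from compound 1 to compound 3 (within the scatter). Among these three compounds, therefore, 2-methylpiperidin-1-yl, with its one six-membered non-aromatic ring, cannot be told apart from 5-chloro-2,3-dihydro-1H-indol-1-yl or methyl(pyridin-3-yl)amino, so an aromatic ring in this group is not required to retain the read-out at the one concentration tested. Nothing measured here bears on why the three groups read alike.

The compounds shown leave open whether a group carrying a free amine or a carboxylic acid on this carbon would also leave the read-out unchanged. They also leave open whether the three groups would give a stronger or weaker effect at any other concentration, since only one concentration was tested.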